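The compounds below may be only part of what the source reports. "The series", "measured", "known", "first", "only" and "open" are said of these compounds alone.

Working notes on the series. Two compounds sharing the core of compound 1 `O=C(NO)c1ccc(NCc2nc(-c3cccs3)nn2-c2ccc(O)cc2)cc1` have been run in a functional assay on MGC-803 cells (Homo sapiens) for antiproliferative activity, read by MTT assay, with a stated time of 72 h; a higher number here means a weaker inhibitor, a lower number a stronger inhibitor. For compound 1 the result is a limit of the assay, > 20000 nM, and not a number. Among the measured compounds shown here, compound 2 `O=C(NO)c1ccc(NCc2nc(-c3ccccc3)nn2-c2ccccc2Cl)cc1` gives 9630 nM in this assay, the only measured number in the set, so compound 2 stands as the sole fixed point; the other result is the limit of > 20000 nM in this assay, at which 1 of the 2 values shown sits. For the measured compounds named here, no step between measured compounds exists, so nothing directly calibrates the change to compound 3 `COc1ccc(-n2nc(-c3ccccc3)nc2CNc2ccc(C(=O)NO)cc2)cc1`, which differs from compound 2 by 4-methoxyphenyl in place of 2-chlorophenyl on an aromatic nitrogen. With the set as thin as this, the step from compound 2 to compound 3 is expected to be modest and toward weaker inhibition, a 1.6-fold higher number from compound 2 to compound 3 (0.19 log units; within the scatter). Compound 3 is estimated at 15000 nM in this assay, with a range from 6000 nM to 40000 nM, and a real chance that only a limit is reported.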

Compound 3, half-maximal inhibitory concentration: 7050 nM
The estimate for compound 3 lay 2.1-fold (0.33 log units) above the measured number; the range from low to high includes it.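

In this assay, among the compounds shown here, 4-methoxyphenyl in place of 2-chlorophenyl on the aromatic nitrogen gives a 1.4-fold lower number from compound 2 to compound 3 (0.14 log units; within the scatter), the first step that can be read at this position. With the phenyl group on the ring held constant, these two substituted phenyl groups cannot be told apart, so this change does not separate compound 2 and compound 3 in this read-out. Nothing shown gives a cause for this step.

For the compounds shown here, compound 1 stands at > 20000 nM, a limit of the assay and not a number, and it differs from both other compounds in more than one place, so no step to it can be read. Open, on these data alone, is whether an amine or a carboxylic acid on this phenyl ring, or a longer chain on the aromatic nitrogen, would give a step beyond the scatter.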